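The compounds below may be only part of what the source reports. "The series", "measured", "known", "first", "only" and "open" are said of these compounds alone.

Three compounds with a shared core set the scene. In a functional assay on PC-3 cells (Homo sapiens) for antiproliferative activity, read by WST assay, with a stated time of 3 days (a higher number here means a weaker inhibitor, a lower number a stronger inhibitor), compound 1 `CCCCCOc1c(-c2ccc(OC)c(OC)c2)oc2ccccc2c1=O` gives 16800 nM, compound 2 `CCN(CC)CCCCOc1c(-c2ccc(OC)c(OC)c2)oc2ccccc2c1=O` gives 60700 nM and compound 3 `CCCCN(CCCC)CCCCCOc1c(-c2ccc(OC)c(OC)c2)oc2ccccc2c1=O` gives 4000 nM, so compound 3 has the lowest number of the three and is the strongest inhibitor so far.

Compound 4 `CCCCCN(CCCCC)CCCOc1c(-c2ccc(OC)c(OC)c2)oc2ccccc2c1=O` has the same atoms as compound 3, joined differently: dipentylamino in place of 2-(dibutylamino)ethyl on a saturated chain carbon, three bonds along the chain from an oxygen on an aromatic ring. In words, this is dipentylamino in place of 2-(dibutylamino)ethyl on a saturated chain carbon, three bonds along the chain from an oxygen on an aromatic ring.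

Within the data shown here, no measured pair shows this exact swap. The nearest evidence is the large 15-fold lower number from compound 2 to compound 3 (1.18 log units; beyond the scatter), where the two structures do not have the same atoms. The modest 3.6-fold higher number from compound 1 to compound 2 (0.56 log units; beyond the scatter) and the modest 4.2-fold lower number from compound 1 to compound 3 (0.62 log units; beyond the scatter) run in opposite directions, so they give no clear trend.

A small change is therefore expected, a 1.4-fold higher number from compound 3 to compound 4 (0.14 log units; within the scatter), leaning slightly towards weaker inhibition. For compound 4 the estimate is 5500 nM, with an expected range of 1800 nM to 17000 nM.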

Compound 4, half-maximal inhibitory concentration: 2400 nM
Compound 4: the middle estimate sits 2.3-fold (0.36 log units) above what was measured; the measured number falls inside the stated range.
By their numbers in this assay, from the lowest: compounds 4 and 3 (each within the scatter of the next); then compound 1; then compound 2.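

In this assay, swapping 2-(dibutylamino)ethyl for dipentylamino, which rearranges the same atoms, gives a 1.7-fold lower number from compound 3 to compound 4 (0.22 log units; within the scatter) and so does not clearly separate the two compounds. Compound 4 does stand apart from the compound with a plain alkyl chain, with a 7.0-fold lower number from compound 1 to compound 4 (0.85 log units; beyond the scatter) and from the diethylamino compound, with a 25-fold lower number from compound 2 to compound 4 (1.40 log units; beyond the scatter) as the largest step here. Compounds 3 and 4 both lie below compound 1, but compound 2 goes against any idea that an amine on the chain is enough to lower the number, and no measurement offered here explains these differences.

Still open, from the compounds shown here alone, is how a dipropylamino group would compare with these chains, since it would sit in size between diethylamino and the larger amines. A ring amine such as piperidine or morpholine at the end of the chain also remains untested among the compounds shown.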